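Three limits and one open step

This account rests on a few compounds, and the source may have more. Where it says the series, first, only, none or still open, it means among the compounds named here.

In a functional assay on SEM cells (Homo sapiens) for cytotoxicity, with a stated time of 72 h (on this read-out higher numbers stand for an effect only at larger amounts of compound and lower numbers for an effect already at smaller amounts), compound 1 (`C=C[C@@](C)(/C=C/c1ccc(O)c(/C=C/C(=O)OCc2ccccc2)c1)CCC=C(C)C`) gives > 36600 nM as a limit. Compound 2 (`C=C[C@@](C)(/C=C/c1ccc(O)c(/C=C/C(N)=O)c1)CCC=C(C)C`) gives > 36600 nM as a limit too. Compound 3 (`C=C[C@@](C)(/C=C/c1ccc(O)c(/C=C(\C)C(=O)OCC)c1)CCC=C(C)C`) stands at > 36600 nM as a limit, so no number is known for it. The two measured steps, a step that the two limits leave unreadable from compound 1 to compound 2 and a step that the two limits leave unreadable from compound 2 to compound 3, offer no size to carry forward. Compound 4 (`C=C[C@@](C)(/C=C/c1ccc(O)c(/C=C/c2ccc(Cl)cc2)c1)CCC=C(C)C`) has 2-(4-chlorophenyl)ethenyl in place of 2-(ethoxycarbonyl)prop-1-en-1-yl on an aromatic carbon, ortho to a hydroxy group (2-(4-chlorophenyl)ethenyl in place of 2-(ethoxycarbonyl)prop-1-en-1-yl on an aromatic carbon). The most likely outcome is that compound 4 also reaches only a limit. The estimate means an at least 1.2-fold lower number from compound 3 to compound 4 (0.08 log units; that floor lies within the scatter) as an expected step, small if real and toward lower numbers. Compound 4 is estimated at 30000 nM with a range from 8000 nM to 60000 nM expected in this assay for it.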

Compound 4, half-maximal effective concentration: > 36600 nM
Compound 4 gave a limit, no number (the forecaster's own chance of this, stated with the estimate: 65%); middle value at least 1.2-fold (0.08 log units) from the limit.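

Compound 4 also gives only a limit, so no step among compounds 1, 2, 3 and 4 can be read: the limit of > 36600 nM in this assay, at which 4 of the 4 values shown sit.

The compounds shown leave open what number any of them would reach, and whether changing the group on this aromatic carbon shifts it at all.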